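A Longer Carbonyl Group at the End of the Chain

The source may hold more compounds than are shown below. What is called first, only, known or untested is meant among the compounds shown, and "the series" means these compounds.

Three measured compounds share one core and differ only at the end of a short side chain. In a functional assay on MDA-MB-231 cells (Homo sapiens) for cytotoxicity, read by MTT assay, with a stated time of 72 h (a higher number here means a weaker inhibitor, a lower number a stronger inhibitor), compound 1, `COc1ccc(/C(=C(/CCCl)c2ccccc2)c2ccccc2)cc1`, gives only a limit, > 50000 nM. Compound 2, `COc1ccc(/C(=C(/CCNC(=O)N2CCOCC2)c2ccccc2)c2ccccc2)cc1`, gives 42800 nM in this assay. Compound 3, `CCN(CC)C(=O)NCC/C(=C(\c1ccccc1)c1ccc(OC)cc1)c1ccccc1`, gives 40700 nM in this assay. Among the two actual numbers, compound 3 stands at the lower one, with compound 2 nearest, and a 1.1-fold lower number from compound 2 to compound 3 (0.02 log units; within the scatter), which lies within the scatter. Starting from the limit of compound 1, an at least 1.1-fold lower number from compound 1 to compound 2 (0.06 log units; that floor lies within the scatter) and an at least 1.2-fold lower number from compound 1 to compound 3 (0.08 log units; that floor lies within the scatter), both floors that also lie within the scatter.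

Compound 4, `COc1ccc(/C(=C(/CCNC(=O)C(=O)N2CCCCC2)c2ccccc2)c2ccccc2)cc1`, differs from compound 3 in one place: (piperidin-1-yl)carbonyl in place of diethylamino on a carbonyl carbon. The change sits on the same carbonyl carbon that was altered between compound 2 and compound 3. Among the compounds with values here, that step stayed within the scatter, and the two steps away from compound 1 give only floors that are within the scatter, so none of the measured steps at this end of the chain reaches beyond the usual variation. The step from compound 3 to compound 4 is therefore expected to stay within the scatter, a 1.0-fold lower number from compound 3 to compound 4 (0.01 log units; within the scatter). For compound 4 the expected value in this assay is 40000 nM, with a range from 20000 nM to 80000 nM.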

Compound 4, half-maximal inhibitory concentration: > 50000 nM
Compound 4: only a limit was reported; the forecaster's own chance of this, stated with the estimate: 30%; middle value at least 1.2-fold (0.09 log units) from the limit.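

In this assay, within the data shown here, compound 4 gives only a limit, > 50000 nM, and so it is the first compound with a group on this carbonyl carbon that gives no actual number, since the morpholin-4-yl and diethylamino groups both gave one. On these data alone, replacing those groups with (piperidin-1-yl)carbonyl, which brings a six-membered non-aromatic ring and a further carbonyl to the end of the chain, gives an at least 1.2-fold higher number from compound 3 to compound 4 (0.08 log units; that floor lies within the scatter) and an at least 1.1-fold higher number from compound 2 to compound 4 (0.06 log units; that floor lies within the scatter), so each step has only a floor, and its full size remains unknown. The step between compound 1 and compound 4 cannot be read, because both compounds stop at the same limit of the assay: the limit of > 50000 nM in this assay, at which 2 of the 4 values shown sit.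

Placing a piperidin-1-yl group directly on the single carbonyl would help to separate the contribution of the ring from that of the added carbonyl. As far as these compounds go, it also remains open whether a plain amine, a carboxylic acid or a longer chain at this end of the side chain would give a number clearly beyond the scatter of those for compound 2 and compound 3.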